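The compounds below may be only part of what the source reports. "The series", "measured", "known", "first", "only" and "open" are said of these compounds alone.

Measured compounds in an assay on HEK293 cells for agonist activity at transient receptor potential cation channel subfamily M member 8 (Homo sapiens), read by fluorescence and calcium flux, with a stated time of 15 min; on this read-out higher numbers stand for an effect only at larger amounts of compound and lower numbers for an effect already at smaller amounts:
Compound 1 `Cc1ccc(OCC(=O)N(Cc2cccs2)C2CCCCC2)cc1`; in this assay compound 1 gives 40000 nM.
Compound 2 `Cc1ccc(OCC(=O)N(Cc2cccs2)c2nccs2)cc1`; in this assay compound 2 gives 2240 nM.
Compound 3 `COCCN(Cc1cccs1)C(=O)COc1ccc(C)cc1`; in this assay compound 3 gives 400 nM.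

Compound 3 holds the lowest number of the three; the nearest is compound 2, a 5.6-fold lower number from compound 2 to compound 3 (0.75 log units; beyond the scatter), and the furthest compound 1, a 100-fold lower number from compound 1 to compound 3 (2.00 log units; beyond the scatter).

Compound 4 `Cc1ccc(OCC(=O)N(Cc2cccs2)c2ncco2)cc1` differs from compound 3 in one place: 1,3-oxazol-2-yl in place of 2-methoxyethyl on an amide-type nitrogen. The step that bears on it is a 5.6-fold lower number from compound 2 to compound 3 (0.75 log units; beyond the scatter), run in reverse with a related five-membered aromatic ring in place of 1,3-thiazol-2-yl; an 18-fold lower number from compound 1 to compound 2 (1.25 log units; beyond the scatter) shows such a ring already well below cyclohexyl. Among the compounds with values here, the 1,3-oxazol-2-yl group itself has no measured counterpart here. A modest rise in number is therefore expected for compound 4, a 5.0-fold higher number from compound 3 to compound 4 (0.70 log units; beyond the scatter).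

Compound 4 is estimated at 2000 nM in this assay, with a range from 600 nM to 7000 nM.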

Compound 4, half-maximal effective concentration: 0.3 nM
Compound 4: middle estimate off by 6700-fold (3.82 log units), on the high side, outside the stated range (below it).
By their numbers in this assay, from the lowest: compound 4; then compound 3; then compound 2; then compound 1.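

In this assay, within the data shown here, the group on the amide-type nitrogen controls the read-out far more strongly than the earlier compounds indicated: 1,3-oxazol-2-yl gives a 1300-fold lower number from compound 3 to compound 4 (3.12 log units; beyond the scatter) against 2-methoxyethyl and a 130000-fold lower number from compound 1 to compound 4 (5.12 log units; beyond the scatter) against cyclohexyl. Five-membered aromatic rings at this position are not interchangeable, since 1,3-oxazol-2-yl in place of 1,3-thiazol-2-yl gives a 7500-fold lower number from compound 2 to compound 4 (3.87 log units; beyond the scatter) and the 1,3-thiazol-2-yl compound does not surpass the 2-methoxyethyl compound. No measurement available here explains the size of this change.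

Still open, going by these compounds, is whether 1,2-oxazol-3-yl, 1,3,4-oxadiazol-2-yl or a methyl-bearing 1,3-oxazol-2-yl would keep such a low number. On these data alone, whether the step carries over to other versions of the shared core also remains open.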